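Pyridin-3-yl in place of 4-chlorophenyl on the amide nitrogen

A few compounds are considered here, and "the series" means these few. Any claim that something is new, unique, unknown or untested is made for them only; others in the source may bear on it.

Measured compounds:
- compound 1, `CO[C@@H]1CC=C2NN(c3cc(Cl)cc(Cl)c3)C(=O)C[C@]2(c2ccncc2)O1`: 7500 nM
- compound 2, `CO[C@@H]1CC=C2NN(c3ccc(Cl)cc3)C(=O)C[C@]2(C)O1`: 25500 nM
- compound 3, `CO[C@@H]1CC=C2NN(c3ccc(C)cc3)C(=O)C[C@]2(c2ccccc2)O1`: 8110 nM

Of the compounds shown here, three sharing one core have been measured in a functional assay on A549 cells (Homo sapiens) for inhibition, read by sulforhodamine B assay, with a stated time of 48 h; a higher number here means a weaker inhibitor, a lower number a stronger inhibitor. Compound 1 gives 7500 nM and compound 3 gives 8110 nM. Compound 2 gives 25500 nM, the highest of the three numbers; its gap to compound 3 and its gap to compound 1 both lie beyond the scatter, so compound 2 is the weakest inhibitor of the three. For the measured compounds named here, no single-point step between measured compounds is available, so nothing is known about how a change on the amide-type nitrogen moves the read-out.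

Compound 4, `CO[C@@H]1CC=C2NN(c3cccnc3)C(=O)C[C@]2(C)O1`, is not yet measured. It differs from compound 2 in one place: pyridin-3-yl in place of 4-chlorophenyl on an amide-type nitrogen in a ring. Without a comparable step to lean on, the expectation is anchored to compound 2 and its 25500 nM, with wide uncertainty in both directions. The expected step of a 1.2-fold higher number from compound 2 to compound 4 (0.07 log units; within the scatter) is small and within the scatter. Compound 4 is estimated at 30000 nM, with a range from 10000 nM to 90000 nM.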

Compound 4, half-maximal inhibitory concentration: 14400 nM
Beside the measured number, compound 4's estimate is 2.1-fold (0.32 log units) above it, within the range that was stated.
By their numbers in this assay, from the lowest: compounds 1, 3, 4 and 2 (each within the scatter of the next, the first and the last beyond it).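

In this assay, the amide-type nitrogen now has its first single-place comparison, a 1.8-fold lower number from compound 2 to compound 4 (0.25 log units; within the scatter). With the methyl group kept, 4-chlorophenyl and pyridin-3-yl cannot be told apart in this read-out, so removing the chlorine and introducing a ring nitrogen with a hydrogen-bond acceptor does not produce a separable change at this position. No supporting measurement bears on why the two groups read alike.

The compounds shown leave open whether the same swap would also read alike in compounds carrying phenyl or pyridin-4-yl in place of the methyl group. They also leave open how this nitrogen would respond to pyridin-2-yl, to a saturated piperidine ring, or to a phenyl ring carrying an amine or a carboxylic acid.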